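Moving a Ring Nitrogen: From Compound 1 to Compound 3

A few compounds are considered here, and "the series" means these few. Any claim that something is new, unique, unknown or untested is made for them only; others in the source may bear on it.

Of the compounds shown here, two that share one core have been measured so far. Compound 1 `Nc1ccccc1NC(=O)c1ccc(CSC(=S)N2CCN(c3cccnc3)CC2)cc1` and compound 2 `Nc1ccccc1NC(=O)c1ccc(CSC(=S)N2CCc3cc(Cl)ccc32)cc1` were both tested in a functional assay on HeLa cells (Homo sapiens) for antiproliferative activity, read by CCK-8 assay, with a stated time of 72 h, tested at 2 uM; on this read-out lower numbers stand for a weaker effect and higher numbers for a stronger effect at the one concentration tested. In this assay compound 1 gives 66.2%, and compound 2 gives 40.1%. Of these two numbers, compound 1 holds the higher one, and the gap to compound 2 is wider than the usual scatter of the measurement, so compound 1 stands as the stronger of the pair.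

Compound 3 `Nc1ccccc1NC(=O)c1ccc(CSC(=S)N2CCN(c3ccncc3)CC2)cc1` has not yet been measured in this assay. It keeps every atom of compound 1 but joins them differently: pyridin-4-yl in place of pyridin-3-yl on an amine nitrogen in a ring. The change amounts to pyridin-4-yl in place of pyridin-3-yl on an amine nitrogen in a ring; nothing else is altered.

For the measured compounds named here, no measured pair shows what such a change does here. The step expected from this change is a number 4.2 percentage points lower from compound 1 to compound 3 (within the scatter), small and within the scatter rather than a clear shift in either direction. Compound 3 is therefore estimated to give 62% in this assay, with a likely range from 42% to 78%.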

Compound 3, a percentage reported as inhibition, at one concentration (the size of the read-out at that concentration, not a potency): 77%
Beside the measured number, compound 3's estimate is 15 percentage points below it, and the stated range covers the measured number.
By their numbers in this assay, from the lowest: compound 2; then compound 1; then compound 3.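

For the compounds shown here, compound 3 supplies the first measured pair that isolates this change: in this assay, pyridin-4-yl in place of pyridin-3-yl on the amine nitrogen in the ring gives a number 10.8 percentage points higher from compound 1 to compound 3 (beyond the scatter), a modest step. The two groups match in every count computed for them, including heavy atoms, hydrogen-bond donors and hydrogen-bond acceptors, and both are six-membered aromatic rings with one hetero atom, so the step shows that the read-out at this site can respond to how the same atoms are joined, not only to which atoms are present. Nothing available here accounts for the size or direction of this step.

What the compounds shown leave open is how the same site responds to other rings, such as pyridin-2-yl or a plain phenyl ring, and so whether the trend continues with a different placement of the ring nitrogen or depends on having a ring nitrogen at all. Since this assay reports the effect at a single concentration, the step also leaves open how compound 1 and compound 3 compare across a range of concentrations.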